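Compound 3 gives up its 2,3-dimethyloxiran-2-yl group

A few compounds are considered here, and "the series" means these few. Any claim that something is new, unique, unknown or untested is made for them only; others in the source may bear on it.

In a functional assay on HeLa cells (Homo sapiens) for cytotoxicity, read by MTT assay, with a stated time of 24 h (on this read-out lower numbers stand for stronger inhibition and higher numbers for weaker inhibition), compound 3 (`C[C@H]1O[C@]1(C)C(=O)C[C@H]1[C@](C)(O)CC[C@@]2(O)C(C)(C)CCC[C@]12C`) gives > 10000 nM, which is a limit of the assay and not a number. Compound 1 (`C[C@H]1O[C@]1(C)C(=O)C[C@@H]1[C@@]2(C)[C@@H](O)CCC(C)(C)[C@]2(O)CC[C@@]1(C)O`) also reports only a limit, > 10000 nM. Compound 2 (`C[C@@H]1O[C@@]1(C)C(=O)C[C@@H]1[C@@]2(C)[C@@H](O)CCC(C)(C)[C@]2(O)CC[C@@]1(C)O`) likewise reports only a limit, > 10000 nM. All the evidence so far therefore comes from the limit of > 10000 nM in this assay, at which 3 of the 3 values shown sit, and compound 3 has no numerical position within the set.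

The next structure is compound 4 (`C/C=C(\C)C(=O)C[C@H]1[C@](C)(O)CC[C@@]2(O)C(C)(C)CCC[C@]12C`). The change is 1-methylprop-1-en-1-yl in place of 2,3-dimethyloxiran-2-yl on a carbonyl carbon.

Among the compounds with values here, two measured steps bear on this change: a step that the two limits leave unreadable from compound 1 to compound 2, and a step that the two limits leave unreadable from compound 1 to compound 3. Neither has a readable size because of the limit of > 10000 nM in this assay, at which 3 of the 3 values shown sit, so neither offers a size or direction to carry over. The expectation therefore rests on compound 3 at > 10000 nM, a limit. The expected change in this assay is a step that the limit leaves unreadable from compound 3 to compound 4, an estimate with no direction beyond the usual scatter. For compound 4 the estimated value is 15000 nM, with an expected range from 6000 nM to 40000 nM.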

Compound 4, half-maximal inhibitory concentration: > 10000 nM
Compound 4 ended at the assay's limit; the forecaster's own chance of this, stated with the estimate: 75%; the middle value does not contradict the limit.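

No size or direction can be read for 1-methylprop-1-en-1-yl in place of 2,3-dimethyloxiran-2-yl between compound 3 and compound 4, because each reports only a limit and not a number: the limit of > 10000 nM in this assay, at which 4 of the 4 values shown sit.

The compounds shown leave open which structural features, if any, would give a measurable value in this assay.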